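Changing the Ring on the Amine Nitrogen

This account rests on a few compounds, and the source may have more. Where it says the series, first, only, none or still open, it means among the compounds named here.

Compound 2 `Nc1scc(CN2CCN(c3ccncc3)CC2)c1C(=O)c1ccc(Cl)cc1` was tested in an assay on CHO cells for displacement of a labelled ligand from adenosine receptor A3 (Homo sapiens), read by scintillation counting, with a stated time of 120 min, tested at 10 uM (a higher number here means more inhibition at the concentration tested (going by the name of the read-out), a lower number less inhibition), where compound 2 gives 2%. Compound 1 `Nc1scc(CN2CCN(c3ccc(F)cc3Cl)CC2)c1C(=O)c1ccc(Cl)cc1`, which carries 2-chloro-4-fluorophenyl on the same amine nitrogen in a ring, gives 0%. The step between them, a number 2 percentage points higher from compound 1 to compound 2 (within the scatter), lies within the scatter, so the two values show essentially no inhibition and cannot be ordered. Compound 3 `Nc1scc(CN2CCN(c3cccc(Cl)c3)CC2)c1C(=O)c1ccc(Cl)cc1` is the next compound: 3-chlorophenyl in place of pyridin-4-yl on an amine nitrogen in a ring. Among the measured compounds shown here, the one measured step that bears on it is the exchange of one aromatic ring for another on this same nitrogen, a number 2 percentage points higher from compound 1 to compound 2 (within the scatter), which stayed within the scatter even though pyridin-4-yl replaced 2-chloro-4-fluorophenyl. A change of this kind is therefore expected to leave the read-out near zero, with no step beyond the scatter. Compound 3 is estimated at 1%, between -8% and 12%. That estimate means an expected step of a number 1 percentage points lower from compound 2 to compound 3 (within the scatter).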

Compound 3, a percentage reported as inhibition, at one concentration (the size of the read-out at that concentration, not a potency): 1%
Compound 3: middle estimate and measured number agree at the digits printed; the measured number falls inside the stated range.
By their numbers in this assay, from the lowest: compounds 1, 3 and 2 (each within the scatter of the next).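

With 3-chlorophenyl on the amine nitrogen in a ring, this assay shows a number 1 percentage points lower from compound 2 to compound 3 (within the scatter), and against the 2-chloro-4-fluorophenyl group it shows a number 1 percentage points higher from compound 1 to compound 3 (within the scatter). The position has now carried three different six-membered aromatic rings, one with a ring nitrogen and two of carbon only with halogens, and all three stay close to zero inhibition, so exchanging the hydrogen-bond acceptor of pyridin-4-yl for a chlorine-bearing carbon ring gives no readable step. Nothing measured here offers a reason for this flat result.

Still open, on these data alone, is whether any group at this nitrogen can lift the number clear of zero, for example a non-aromatic group such as a short alkyl chain ending in a carboxylic acid. As far as these compounds go, all three compounds share everything but this ring, so whether a change elsewhere on the shared core would matter more also stays open.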